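The source may hold more compounds than are shown below. What is called first, only, known or untested is meant among the compounds shown, and "the series" means these compounds.

Values in a functional assay on KYSE-450 cells (Homo sapiens) for inhibition, read by MTT assay, with a stated time of 48 h (a higher number here means a weaker inhibitor, a lower number a stronger inhibitor), for the three measured compounds:

Compound 1, `COCC(=O)N(Cc1ccc(OC)c(O)c1)c1cc(OC)c(OC)c(OC)c1`: 460 nM
Compound 2, `COc1ccc(CN(C(C)=O)c2cc(OC)c(OC)c(OC)c2)cc1O`: 160 nM
Compound 3, `CCC/C=C/C(=O)N(Cc1ccc(OC)c(O)c1)c1cc(OC)c(OC)c(OC)c1`: 57 nM

Compound 3 stands lowest of the three numbers. The two steps that lead to it are a 2.8-fold lower number from compound 2 to compound 3 (0.45 log units; beyond the scatter) and an 8.1-fold lower number from compound 1 to compound 3 (0.91 log units; beyond the scatter); the remaining step is a 2.9-fold lower number from compound 1 to compound 2 (0.46 log units; beyond the scatter). All three changes sit on the same carbonyl carbon of the shared core, and each one is beyond the scatter but modest in size.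

Compound 4, `C=CC(=O)N(Cc1ccc(OC)c(O)c1)c1cc(OC)c(OC)c(OC)c1`, is not yet measured. The change from compound 3 is vinyl in place of pent-1-en-1-yl on a carbonyl carbon. Vinyl keeps the one double bond outside aromatic rings but is the shorter chain, so it lies between the methyl of compound 2 and the pent-1-en-1-yl of compound 3. The step that bears most directly is a 2.8-fold lower number from compound 2 to compound 3 (0.45 log units; beyond the scatter), with an 8.1-fold lower number from compound 1 to compound 3 (0.91 log units; beyond the scatter) pointing the same way; both show that a longer group on this carbonyl carbon gave a lower number. Shortening it again is therefore expected to move the number back up, but by less than the full step from compound 2 to compound 3, probably close to the edge of the scatter: the estimated step is a 1.8-fold higher number from compound 3 to compound 4 (0.24 log units; within the scatter). Compound 4 is expected to give about 100 nM in this assay, with a likely range from 45 nM to 250 nM.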

Compound 4, half-maximal inhibitory concentration: 160 nM
Compound 4: middle estimate off by 1.6-fold (0.20 log units), on the low side, within the range that was stated.
By their numbers in this assay, from the lowest: compound 3; then compounds 2 and 4 (each within the scatter of the next); then compound 1.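

Working notes on the carbonyl carbon: in this assay, vinyl in place of methyl gives no change at the digits printed from compound 2 to compound 4 (within the scatter), so a double bond outside aromatic rings does not, on this pair, separate vinyl from methyl. With that double bond held constant, the shorter chain gives a 2.8-fold higher number from compound 3 to compound 4 (0.45 log units; beyond the scatter), which places the gain seen in compound 3 with the pent-1-en-1-yl group as a whole rather than with the presence of a double bond alone. Vinyl in place of methoxymethyl gives a 2.9-fold lower number from compound 1 to compound 4 (0.46 log units; beyond the scatter), so compound 1 stays apart from both the vinyl and the methyl amides, and no line of measured evidence explains any of these steps.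

Still open, from the compounds shown here alone, is whether a saturated pentyl group on this carbonyl carbon would match compound 3, which would show whether the double bond matters once the chain is long. Also open, going by these compounds, is whether a longer chain would take the number lower still, and how an amine or a carboxylic acid at the end of such a chain would read in this assay.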